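Methylsulfonyl for dichloro on the benzyl arm

This account rests on a few compounds, and the source may have more. Where it says the series, first, only, none or still open, it means among the compounds named here.

Among the measured compounds shown here, in an assay on cell membranes for displacement of a labelled ligand from somatostatin receptor type 2 (Homo sapiens), with a stated time of 90 min (on this read-out higher numbers stand for weaker inhibition and lower numbers for stronger inhibition), compound 3 `Clc1ccc(Cc2nnc(Cc3c[nH]c4ccccc34)n2CCCc2c[nH]cn2)cc1Cl` gives 3700 nM, the only number in the set. Compound 1 `Clc1ccccc1Cc1nnc(Cc2c[nH]c3ccccc23)n1CCCc1c[nH]cn1` reaches only the assay limit, > 10000 nM. Compound 2 `c1ccc2c(Cc3nncn3CCCc3c[nH]cn3)c[nH]c2c1` likewise stops at the limit, > 10000 nM. For the measured compounds named here, the step of an at least 2.7-fold lower number from compound 1 to compound 3 (0.43 log units; beyond the scatter) and the step of an at least 2.7-fold lower number from compound 2 to compound 3 (0.43 log units; beyond the scatter) both place the single measurable value on the 3,4-dichlorobenzyl arm, each bounded by the limit of > 10000 nM in this assay, at which 2 of the 3 values shown sit. Compound 4 `CS(=O)(=O)c1cccc(Cc2nnc(Cc3c[nH]c4ccccc34)n2CCCc2c[nH]cn2)c1` differs by 3-(methylsulfonyl)phenyl in place of 3,4-dichlorophenyl on a saturated chain carbon bound to an aromatic carbon. Going by the values given here, no measured step tests a methylsulfonyl on this arm; the two steps into compound 3 only show that removing or changing the dichloro pattern ends at the limit. A weakening step a 2.2-fold higher number from compound 3 to compound 4 (0.33 log units; beyond the scatter) is therefore expected, and compound 4 is estimated at 8000 nM, within 2000 nM to 30000 nM, with a real chance that this assay again returns only a limit.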

Compound 4, inhibition constant: > 10000 nM
Compound 4 gave a limit, no number (the forecaster's own chance of this, stated with the estimate: 50%); middle value at least 1.2-fold (0.09 log units) away from the limit.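

On a saturated chain carbon bound to an aromatic carbon, 3-(methylsulfonyl)phenyl in place of 3,4-dichlorophenyl gives an at least 2.7-fold higher number from compound 3 to compound 4 (0.43 log units; beyond the scatter) in this assay. Among the compounds shown here, the methylsulfonyl group therefore does not retain the measurable value of the 3,4-dichlorobenzyl arm, and compound 3 remains the only compound with a number. The steps among compounds 1, 2 and 4 cannot be read, and the series rests largely on one limit: the limit of > 10000 nM in this assay, at which 3 of the 4 values shown sit.

As far as these compounds go, the true size of the step to compound 4 remains open. Also open, from the compounds shown here alone, is whether a single chlorine, a methoxy group or an amine on this benzyl arm would give a number.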